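The source may hold more compounds than are shown below. What is called first, only, known or untested is meant among the compounds shown, and "the series" means these compounds.

Of the compounds shown here, three built on the same core have been tested in an ADME assay on A549 cells (Homo sapiens) for cytotoxicity, read by resazurin assay, with a stated time of 48 h; on this read-out lower numbers stand for higher toxicity in this test and higher numbers for lower toxicity in this test. Compound 1 `CC(C)CNc1ccc(NC(=O)c2cc(Cl)ccc2O)c(Cl)c1` gives 60000 nM in this assay. Compound 2 `O=C(Nc1ccc(NC2CCCCC2)cc1Cl)c1cc(Cl)ccc1O` gives 68300 nM in this assay. Compound 3 `COc1ccc(CNc2ccc(NC(=O)c3cc(Cl)ccc3O)c(Cl)c2)cc1` gives 80700 nM in this assay. On the numbers shown, compound 3 carries the top figure of the three, yet the gaps are small: a 1.3-fold higher number from compound 1 to compound 3 (0.13 log units; within the scatter) and a 1.2-fold higher number from compound 2 to compound 3 (0.07 log units; within the scatter), so the three compounds cannot be told apart here. The same holds for the pair below them: a 1.1-fold higher number from compound 1 to compound 2 (0.06 log units; within the scatter). All three steps swap the group on the nitrogen on the aromatic ring, and none of them shifts the number beyond the scatter.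

Compound 4 `CC(C)(CCO)Nc1ccc(NC(=O)c2cc(Cl)ccc2O)c(Cl)c1` has not yet been measured. It differs from compound 3 in one place: 3-hydroxy-1,1-dimethylpropyl in place of 4-methoxybenzyl on a nitrogen on an aromatic ring. Since every measured exchange at this position left this assay unmoved, no step beyond the scatter is expected here, and the step from compound 3 to compound 4 is estimated at a 1.1-fold lower number from compound 3 to compound 4 (0.05 log units; within the scatter). The value expected for compound 4 in this assay is 72000 nM, with a range from 35000 nM to 150000 nM.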

Compound 4, half-maximal cytotoxic concentration: 170000 nM
Beside the measured number, compound 4's estimate is 2.4-fold (0.37 log units) below it; measured number outside the range, above it.
By their numbers in this assay, from the lowest: compounds 1, 2 and 3 (each within the scatter of the next); then compound 4.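

In this assay, the group on a nitrogen on an aromatic ring can move the number beyond the scatter after all, with a 2.1-fold higher number from compound 3 to compound 4 (0.32 log units; beyond the scatter) and a 2.5-fold higher number from compound 2 to compound 4 (0.40 log units; beyond the scatter) and a 2.8-fold higher number from compound 1 to compound 4 (0.45 log units; beyond the scatter). Compared with 4-methoxybenzyl, the entering 3-hydroxy-1,1-dimethylpropyl has fewer heavy atoms, has no ring and adds a hydrogen-bond donor, and this single exchange cannot separate those differences. No measurement here bears on what lies behind the higher number.

On these data alone, it remains open whether the hydroxyl matters at all, and a plain 1,1-dimethylpropyl group would test that directly. An amine or a carboxylic acid in place of the hydroxyl, or a longer chain carrying the hydroxyl, would show how far the number at this position can be pushed.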